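Swapping a Cyclopropyl Chain for a Methoxypropyl Chain

A few compounds are considered here, and "the series" means these few. Any claim that something is new, unique, unknown or untested is made for them only; others in the source may bear on it.

Compound 1 `Cc1nc(N[C@H](C)C2CC2)nc(N[C@@H]2C[C@H](C(C)(C)O)[C@@H](O)[C@H]2O)c1-c1nc2c(C)nccc2s1` was tested in an ADME assay on cells (Homo sapiens) for inhibition, read by scintillation proximity assay and thymidine incorporation, with a stated time of 3 days; a lower number here means that less compound is tolerated, a higher number that more compound is tolerated. In this assay compound 1 reaches only a limit, > 25000 nM, so no exact number exists for it. Its standing is the limit of > 25000 nM in this assay, at which 1 of the 2 values shown sits. Compound 2 `COCC(O)(COC)[C@H]1C[C@@H](Nc2nc(NCC3CC3)nc(C)c2-c2nc3c(C)nccc3s2)[C@H](O)[C@@H]1O`, built differently in several places, gives 4000 nM in this assay. Compound 3 `CO[C@H](C)CNc1nc(C)c(-c2nc3c(C)nccc3s2)c(N[C@@H]2C[C@H](C(C)(C)O)[C@@H](O)[C@H]2O)n1` is not yet measured; its change from compound 1 is 2-methoxypropyl in place of 1-cyclopropylethyl on a nitrogen on an aromatic ring, in words 2-methoxypropyl in place of 1-cyclopropylethyl on a nitrogen on an aromatic ring. Among the compounds with values here, no measured pair shows this change, so the step expected in this assay, an at least 1.2-fold lower number from compound 1 to compound 3 (0.09 log units; that floor lies within the scatter), is none beyond the scatter. Compound 3 is estimated at 20000 nM, between 6000 nM and 60000 nM.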

Compound 3, half-maximal cytotoxic concentration: 25000 nM
Compound 3: the middle estimate sits 1.3-fold (0.10 log units) below what was measured; low and high end bracket the measured number.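

Within the data shown here, this is the first look at a change on this nitrogen on an aromatic ring, and in this assay the step reads a number no higher from compound 1 to compound 3 (the limit leaves the size open). Compound 3 gives an exact value, 25000 nM. Compound 1 has only a limit, so the size of the step cannot be read: the limit of > 25000 nM in this assay, at which 1 of the 3 values shown sits.

This single swap cannot separate the loss of the three-membered ring from the arrival of the oxygen. From the compounds shown here alone, how a longer chain ending in an amine on this nitrogen would read in this assay remains open.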